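Morpholin-4-yl for pyrrolidin-1-yl on a thiocarbonyl carbon

A few compounds are considered here, and "the series" means these few. Any claim that something is new, unique, unknown or untested is made for them only; others in the source may bear on it.

Compound 1 `COc1ccc(-c2coc3cc(OCCCSC(=S)N4CCN(C)CC4)ccc3c2=O)cc1`: 21900 nM
Compound 2 `COc1ccc(-c2coc3cc(OCCCSC(=S)N4CCN(C(C)=O)CC4)ccc3c2=O)cc1`: 39400 nM
Compound 3 `COc1ccc(-c2coc3cc(OCCCSC(=S)N4CCCC4)ccc3c2=O)cc1`: 40000 nM

All three values come from a functional assay on MGC-803 cells (Homo sapiens) for inhibition, read by MTT assay, with a stated time of 48 h; a higher number here means a weaker inhibitor, a lower number a stronger inhibitor. Compound 3 stands within the scatter of the other two, with a 1.8-fold higher number from compound 1 to compound 3 (0.26 log units; within the scatter) and a 1.0-fold higher number from compound 2 to compound 3 (0.01 log units; within the scatter). Compound 4 `COc1ccc(-c2coc3cc(OCCCSC(=S)N4CCOCC4)ccc3c2=O)cc1` has not yet been measured. It carries morpholin-4-yl in place of pyrrolidin-1-yl on a thiocarbonyl carbon. The two steps to compound 3 swap the group at that same place, and neither leaves the scatter, nor does a 1.8-fold higher number from compound 1 to compound 2 (0.26 log units; within the scatter). No step beyond the scatter is therefore expected in this assay. The expected step is a 1.1-fold lower number from compound 3 to compound 4 (0.06 log units; within the scatter). For compound 4 the estimate is 35000 nM, with an expected range of 17000 nM to 70000 nM.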

Compound 4, half-maximal inhibitory concentration: 49600 nM
Compound 4: the middle estimate sits 1.4-fold (0.15 log units) below what was measured, and the stated range covers the measured number.
By their numbers in this assay, from the lowest: compounds 1, 2, 3 and 4 (each within the scatter of the next, the first and the last beyond it).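

In this assay morpholin-4-yl on the thiocarbonyl carbon stays level with pyrrolidin-1-yl (a 1.2-fold higher number from compound 3 to compound 4 (0.09 log units; within the scatter)) and with 4-acetylpiperazin-1-yl (a 1.3-fold higher number from compound 2 to compound 4 (0.10 log units; within the scatter)). Within the data shown here, only its comparison with 4-methylpiperazin-1-yl leaves the scatter, modestly (a 2.3-fold higher number from compound 1 to compound 4 (0.36 log units; beyond the scatter)), making this the first pair of groups at this position that the assay separates. No evidence is available to explain that gap.

The compounds shown leave open whether piperidin-1-yl or an open-chain diethylamino group at this place would fall with compound 1 or with compound 4.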